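A few compounds are considered here, and "the series" means these few. Any claim that something is new, unique, unknown or untested is made for them only; others in the source may bear on it.

Measured in a functional assay on HeLa cells (Homo sapiens) for inhibition, read by CCK-8 assay, with a stated time of 72 h; on this read-out lower numbers stand for stronger inhibition and higher numbers for weaker inhibition:
Compound 1 (`Nc1ccccc1NC(=O)c1ccc(CNC(=O)c2n[nH]cc2NC(=O)c2ccccc2)cc1`): 4060 nM
Compound 2 (`O=C(NO)c1ccc(CNC(=O)c2n[nH]cc2NC(=O)c2c(Cl)cccc2Cl)cc1`): 4840 nM

Compound 2, at 4840 nM, lies within the usual scatter of compound 1, so the two stand level. Compound 3 (`Nc1ccccc1NC(=O)c1ccc(CNC(=O)c2n[nH]cc2NC(=O)c2c(Cl)cccc2Cl)cc1`) has 2-aminophenyl in place of hydroxy on an amide-type nitrogen. Among the measured compounds shown here, no measured pair isolates this change. Compound 1 also carries (2-aminophenyl)carbamoyl and gives 4060 nM, so only a small step toward a lower number is expected in this assay, possibly none beyond the scatter. The expected change is a 1.6-fold lower number from compound 2 to compound 3 (0.21 log units; within the scatter). For compound 3 the estimated value is 3000 nM, with an expected range of 800 nM to 9000 nM.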

Compound 3, half-maximal inhibitory concentration: 1830 nM
Estimate against measurement, compound 3: 1.6-fold (0.21 log units) above, and the stated range covers the measured number.
By their numbers in this assay, from the lowest: compound 3; then compounds 1 and 2 (each within the scatter of the next).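

In this assay, 2-aminophenyl in place of hydroxy on the amide-type nitrogen gives a 2.6-fold lower number from compound 2 to compound 3 (0.42 log units; beyond the scatter) when 2,6-dichlorophenyl is present. With (2-aminophenyl)carbamoyl held constant, 2,6-dichlorophenyl in place of phenyl on the carbonyl carbon gives a 2.2-fold lower number from compound 1 to compound 3 (0.35 log units; beyond the scatter) and so also counts beyond the scatter, although compounds 1 and 2 stand level. Nothing measured here accounts for either step.

The compounds shown leave open how 2-hydroxyphenyl or a plain phenyl on that amide-type nitrogen would compare. They also leave open how hydroxycarbamoyl would read with phenyl on the carbonyl carbon.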